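A few compounds are considered here, and "the series" means these few. Any claim that something is new, unique, unknown or untested is made for them only; others in the source may bear on it.

Measured so far:
compound 1 `Cc1cc(NCc2nccn2C)n2nc(C)c(-c3ccccc3)c2n1` — 26900 nM
compound 2 `Cc1cc(NCc2ccccn2)n2ncc(-c3ccsc3)c2n1` — 9000 nM

Two compounds of the series carry a number in a physicochemical assay for solubility, read by HPLC, using the shake flask method, measured as kinetic solubility, with a stated time of 2 h, at pH 7.4; a lower number here means a less soluble compound, a higher number a more soluble compound. Compound 1 gives 26900 nM and stands highest of the two; compound 2 gives 9000 nM, a gap beyond the usual scatter. The two differ in more than one place, so their values are read side by side and nothing more is drawn from them.

Among the measured compounds shown here, compound 3 `Cc1cc(NCc2ccc(F)cn2)n2nc(C)c(-c3ccccc3)c2n1` has no measurement yet. It differs from compound 1 in one place: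
5-fluoropyridin-2-yl in place of 1-methyl-1H-imidazol-2-yl on a saturated chain carbon bound to a nitrogen on an aromatic ring
For the measured compounds named here, no pair of measured compounds separated by a single change exists here, so the size of the step has to be estimated without a direct precedent. The 5-fluoropyridin-2-yl group that enters is related in kind to the pyridin-2-yl group carried by compound 2, the lower of the two measured compounds, but compound 2 also differs from compound 1 elsewhere, so that comparison is only a loose guide.

For compound 3 a downward step in this assay is expected, of moderate size and probably beyond the scatter, as a 2.2-fold lower number from compound 1 to compound 3 (0.35 log units; beyond the scatter). The estimated value for compound 3 is 12000 nM, with a range from 5000 nM to 30000 nM.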

Compound 3, solubility: < 5000 nM
Compound 3 was reported as a limit; the forecaster's own chance of this, stated with the estimate: 5%; at least 2.4-fold (0.38 log units) between middle value and limit.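

In this assay compound 3 gives < 5000 nM, which is a limit of the assay and not a number. Among the compounds shown here, the series now has a single-place comparison: with the rest of the structure unchanged, 5-fluoropyridin-2-yl in place of 1-methyl-1H-imidazol-2-yl on a saturated chain carbon bound to a nitrogen on an aromatic ring gives an at least 5.3-fold lower number from compound 1 to compound 3 (0.73 log units; beyond the scatter), showing that this position alone can move the read-out beyond the scatter, which the side-by-side reading of the earlier compounds could not show. The step fixes only a bound on the size of the change, not the size itself: the limit of < 5000 nM in this assay, at which 1 of the 3 values shown sits.

As far as these compounds go, whether the step belongs to the fluorine or to the exchange of the ring itself stays open, as compound 2 carries pyridin-2-yl but also differs from compound 1 elsewhere, so it does not separate the two. Also open, from the compounds shown here alone, is how this assay would read with a morpholine, a primary amine or a carboxylic acid at this position on the core of compound 1.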